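A few compounds are considered here, and "the series" means these few. Any claim that something is new, unique, unknown or untested is made for them only; others in the source may bear on it.

Measured compounds:
compound 1, `Cc1cc(C)cc(NC(=O)COc2cc(C)nc3ccc(Cl)cc23)c1`, 8000 nM
compound 2, `COc1cccc(NC(=O)COc2cc(C)nc3ccc(OC)cc23)c1`, 35000 nM
compound 3, `COc1ccc2nc(C)cc(OCC(=O)Nc3ccc(Cl)c(C(F)(F)F)c3)c2c1`, 17000 nM

In a physicochemical assay for solubility, in phosphate buffer, measured as kinetic solubility, with a stated time of 1 h, at pH 7.4 (a lower number here means a less soluble compound, a higher number a more soluble compound), compound 2 gives the highest number of the three. The nearest of the others is compound 3, whose value lies beyond the usual scatter of this assay; the furthest is compound 1, which lies further still. All three share the same core, and they differ in the group carried on the amide-type nitrogen.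

Compound 4, `COc1ccc2nc(C)cc(OCC(=O)Nc3nc(C)c(C)s3)c2c1`, has not yet been measured in this assay. It differs from compound 2 in one place: 4,5-dimethyl-1,3-thiazol-2-yl in place of 3-methoxyphenyl on an amide-type nitrogen. Within the data shown here, no measured pair in this set shows this kind of exchange, so its effect has to be guessed from the set as a whole, where compound 2 holds the top value and the two other groups on the amide-type nitrogen give lower values: compound 1 gives 8000 nM and compound 3 gives 17000 nM. On that basis the step from compound 2 to compound 4 is expected to be a 2.3-fold lower number from compound 2 to compound 4 (0.37 log units; beyond the scatter), a modest fall, though it could also stay within the scatter. The estimated value for compound 4 is 15000 nM, with a likely range from 5000 nM to 45000 nM.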

Compound 4, solubility: 31500 nM
For compound 4 the middle estimate is 2.1-fold (0.32 log units) below the measured one; the measured number falls inside the stated range.
By their numbers in this assay, from the lowest: compound 1; then compounds 3, 4 and 2 (each within the scatter of the next, the first and the last beyond it).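

In this assay, among these compounds, placing 4,5-dimethyl-1,3-thiazol-2-yl instead of 3-methoxyphenyl on the amide-type nitrogen gives a 1.1-fold lower number from compound 2 to compound 4 (0.05 log units; within the scatter), the first step in this set that isolates a single exchange. It shows that, with the shared core held fixed, a five-membered aromatic ring with 2 hetero atoms can take the place of a six-membered aromatic ring of carbon only without moving the number beyond the usual scatter. Nothing measured here bears on the reason for this result.

Other groups on this nitrogen remain open, such as a pyridine ring, a phenyl ring carrying a carboxylic acid, or a thiazole without its two methyl groups. This is also one step on one core, so it leaves open whether the same exchange would behave alike on the core of compound 1.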